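Moving the methyl on the aryl carboxylic acid tail

This account rests on a few compounds, and the source may have more. Where it says the series, first, only, none or still open, it means among the compounds named here.

The pair of measured compounds shares a core that carries a cyclopentylmethyl ketone and a butyl chain linking two aryl ethers. Compound 1 `COc1ccc(C(=O)O)cc1OCCCCOc1ccc(C(=O)CC2CCCC2)c(O)c1C` gives 67.6% in an assay on HEK293 cells for positive allosteric modulation of metabotropic glutamate receptor 3 (Rattus norvegicus), read by thallium flux, with a stated time of 2.5 min; a lower number here means a smaller maximal response, a higher number a larger maximal response. Compound 2 `Cc1cc(C(=O)O)ccc1OCCCCOc1ccc(C(=O)CC2CCCC2)c(O)c1C` gives 28.4% in this assay, the lowest of the two numbers, and the step of a number 39.2 percentage points lower from compound 1 to compound 2 (beyond the scatter) is large. Compound 3 `Cc1cc(OCCCCOc2ccc(C(=O)CC3CCCC3)c(O)c2C)ccc1C(=O)O` is not yet measured. It differs from compound 2 by 4-carboxy-3-methylphenyl in place of 4-carboxy-2-methylphenyl on an oxygen on a saturated carbon. For the measured compounds named here, no measured step changes the position of the methyl on this ring while keeping the carboxylic acid in place, so the only related information is the large loss from compound 1 to compound 2, which does not bear directly on this change. The expectation for compound 3 is therefore wide and centred near compound 2, with a number 9.6 percentage points higher from compound 2 to compound 3 (within the scatter) expected in this assay. Compound 3 is estimated at 38%, within 15% to 70%.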

Compound 3, largest response reached (reported as percent of maximum), in percent of the reference or control that the assay uses: 23.7%
Compound 3: middle estimate off by 14.3 percentage points, on the high side; low and high end bracket the measured number.
By their numbers in this assay, from the lowest: compounds 3 and 2 (each within the scatter of the next); then compound 1.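

Exchanging 4-carboxy-2-methylphenyl for 4-carboxy-3-methylphenyl on an oxygen on a saturated carbon gives a number 4.7 percentage points lower from compound 2 to compound 3 (within the scatter) in this assay, so the two methyl-bearing tails cannot be told apart by this read-out. The large loss is therefore not confined to compound 2: replacing the 5-carboxy-2-methoxyphenyl tail of compound 1 with 4-carboxy-3-methylphenyl gives a number 43.9 percentage points lower from compound 1 to compound 3 (beyond the scatter) in this assay, a step also beyond the scatter. No evidence is available to explain these results.

The compounds shown leave open whether the higher response of compound 1 goes with its methoxy group or with the placement of its carboxylic acid, as the tail of compound 1 differs from the other two in both respects. They also leave open how a tail with a chlorine atom or an amide would behave.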